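The source may report more compounds than this note shows. Statements on the series, on what has been measured and on what is new or still open speak of the compounds shown alone.

In a functional assay on KM12 cells (Homo sapiens) for antiproliferative activity, with a stated time of 48 h (on this read-out higher numbers stand for weaker inhibition of growth and lower numbers for stronger inhibition of growth), three compounds built on one shared core have been measured. Compound 1 `Cc1cc(O)c(C2=NN(c3ccc(S(N)(=O)=O)cc3)C(c3ccccc3O)C2)cc1Cl` gives 1780 nM, and compound 2 `Cc1cc(O)c(C2=NN(c3ccc(S(N)(=O)=O)cc3)C(c3ccccc3Cl)C2)cc1Cl` gives 1980 nM; the step of a 1.1-fold higher number from compound 1 to compound 2 (0.05 log units; within the scatter), chloro in place of hydroxy on an aromatic carbon, leaves the read-out essentially unchanged. Compound 3 `Cc1cc(O)c(C2=NN(c3ccc(S(N)(=O)=O)cc3)C(/C=C/c3ccccc3)C2)cc1Cl` gives 11700 nM, the highest of the three numbers: it lies a 6.6-fold higher number from compound 1 to compound 3 (0.82 log units; beyond the scatter) and a 5.9-fold higher number from compound 2 to compound 3 (0.77 log units; beyond the scatter), both beyond the scatter, so 2-phenylethenyl on the saturated ring carbon goes with weaker inhibition of growth than either aryl group.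

Compound 4 `COc1ccc(C2CC(c3cc(Cl)c(C)cc3O)=NN2c2ccc(S(N)(=O)=O)cc2)cc1OC` has not yet been measured. It differs from compound 3 in one place: 3,4-dimethoxyphenyl in place of 2-phenylethenyl on a saturated ring carbon. The measured steps that bear on this are the two into compound 3, a 6.6-fold higher number from compound 1 to compound 3 (0.82 log units; beyond the scatter) and a 5.9-fold higher number from compound 2 to compound 3 (0.77 log units; beyond the scatter), which show that an aryl group on this carbon is followed by a lower number than the 2-phenylethenyl group. Compound 4 bears 3,4-dimethoxyphenyl rather than the 2-hydroxyphenyl of compound 1 or the 2-chlorophenyl of compound 2, so the exact size of the reverse step is uncertain, but a decrease of broadly similar size is expected. Compound 4 is therefore estimated to give 2500 nM in this assay, with a range from 1200 nM to 6000 nM, the expected step being a 4.7-fold lower number from compound 3 to compound 4 (0.67 log units; beyond the scatter).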

Compound 4, concentration for 50% growth inhibition: 3070 nM
Compound 4: the middle estimate sits 1.2-fold (0.09 log units) below what was measured, and the stated range covers the measured number.
By their numbers in this assay, from the lowest: compounds 1, 2 and 4 (each within the scatter of the next); then compound 3.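

In this assay, the step of a 3.8-fold lower number from compound 3 to compound 4 (0.58 log units; beyond the scatter), with 3,4-dimethoxyphenyl in place of 2-phenylethenyl on the saturated ring carbon, shows that the lower number seen with 2-hydroxyphenyl and 2-chlorophenyl also holds for a third aryl group, one carrying two methoxy groups. The aryl groups themselves are not separated by this read-out: the steps of a 1.6-fold higher number from compound 2 to compound 4 (0.19 log units; within the scatter) and a 1.7-fold higher number from compound 1 to compound 4 (0.24 log units; within the scatter) both stay within the scatter, so hydroxy, chloro and dimethoxy substitution on the ring at this carbon give no distinguishable difference across these compounds. Size in heavy atoms does not order the result either, since the entering group, with 10 heavy atoms, is larger than the 2-phenylethenyl group it replaces, with 8, yet goes with the lower number, leaving 2-phenylethenyl, the only one of these groups with a double bond outside aromatic rings, as the one that stands apart.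

Nothing available here explains why these groups give these numbers. The compounds shown leave open whether a saturated 2-phenylethyl chain would behave like 2-phenylethenyl or like the aryl groups, and what a group with no aromatic ring, such as a plain methyl or an amine, would give on this carbon.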